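Replacing 4-Methylpiperazin-1-yl by (3-Chlorophenyl)amino

The source may report more compounds than this note shows. Statements on the series, on what has been measured and on what is new or still open speak of the compounds shown alone.

The measured compounds:
compound 1, `CN1CCN(c2nc(Cl)nc3c2ncn3Cc2ccc(C(=O)Nc3ccccc3N)cc2)CC1`, 55.1%
compound 2, `CCCn1cnc2c(NCc3ccc(C(=O)Nc4ccccc4N)cc3)nc(Cl)nc21`, 39.2%
compound 3, `CCCCn1cnc2c(Nc3ccccc3)nc(NCOCc3ccc(C(=O)Nc4ccccc4N)cc3)nc21`, 51.3%

In a functional assay on NCI-H460 cells (Homo sapiens) for antiproliferative activity, read by CCK-8 assay, with a stated time of 72 h, tested at 8 uM (on this read-out lower numbers stand for a weaker effect and higher numbers for a stronger effect at the one concentration tested), compound 1 gives 55.1%, the highest of the three numbers. Compound 3 lies close to it, within the scatter, while compound 2 lies beyond the scatter below it. Compound 4, `Nc1ccccc1NC(=O)c1ccc(Cn2cnc3c(Nc4cccc(Cl)c4)nc(Cl)nc32)cc1`, has not yet been measured. It differs from compound 1 in one place: (3-chlorophenyl)amino in place of 4-methylpiperazin-1-yl on an aromatic carbon. Within the data shown here, no pair of measured compounds isolates such a change, so the expectation rests on the spread of the three numbers. Compound 3 gives 51.3%, close to compound 1, and compound 4 is therefore expected to show a step of a number 5.1 percentage points lower from compound 1 to compound 4 (within the scatter), none beyond the scatter. Compound 4 is estimated at 50%, between 32% and 68%.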

Compound 4, a percentage reported as inhibition, at one concentration (the size of the read-out at that concentration, not a potency): 67%
The estimate for compound 4 lay 17 percentage points below the measured number; the range from low to high includes it.
By their numbers in this assay, from the lowest: compound 2; then compounds 3 and 1 (each within the scatter of the next); then compound 4.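

Among these compounds, this is the first step that changes only one place. In this assay, (3-chlorophenyl)amino in place of 4-methylpiperazin-1-yl on this aromatic carbon gives a number 11.9 percentage points higher from compound 1 to compound 4 (beyond the scatter), so the position accepts an aromatic ring in place of a non-aromatic one without losing the effect at the one concentration tested. Nothing available bears on why the number rises. The compounds shown leave open whether the gain belongs to the aromatic ring, its chloro group or the linking amine nitrogen. A morpholin-4-yl group at this carbon, or a methoxy group in place of that chlorine, would help to separate these.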